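From 2-cyanobenzyl to 3-chlorobenzyl in the series

The compounds below may be only part of what the source reports. "The series", "measured", "known", "first", "only" and "open" are said of these compounds alone.

Compound 2 `COC(=O)[C@H](CCSC)NC(=O)c1ccc(NCc2cncn2Cc2ccccc2C#N)cc1-c1ccccc1` sits at the limit of a functional assay on NIH3T3 cells (Mus musculus); on this read-out higher numbers stand for an effect only at larger amounts of compound and lower numbers for an effect already at smaller amounts: in this assay compound 2 gives > 10 uM, which is a limit and not a number. Compound 1 `COC(=O)[C@H](CCSC)NC(=O)c1ccc(NCc2cncn2Cc2ccc(C)cc2)cc1-c1ccccc1` likewise reaches only a limit, giving > 10 uM in this assay. The step that the two limits leave unreadable from compound 1 to compound 2 cannot be read, as the limit of > 10 uM in this assay, at which 2 of the 2 values shown sit, shows. Compound 3 `COC(=O)[C@H](CCSC)NC(=O)c1ccc(NCc2cncn2Cc2cccc(Cl)c2)cc1-c1ccccc1` differs from compound 2 by 3-chlorophenyl in place of 2-cyanophenyl on a saturated chain carbon bound to an aromatic nitrogen. Within the data shown here, no measured step gives a size for a change of this kind, so no effect beyond the scatter is expected in this assay. Compound 3 is expected at 15 uM (range 5 uM to 50 uM). The expected step that the limit leaves unreadable from compound 2 to compound 3 is none beyond the scatter.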

Compound 3, concentration for half-maximal effect: > 10 uM
Compound 3 ended at the assay's limit (the forecaster's own chance of this, stated with the estimate: 75%); the middle value lies beyond the limit too.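

The steps among compound 1, compound 2 and compound 3 cannot be read in this assay, as all three stop at a limit: the limit of > 10 uM in this assay, at which 3 of the 3 values shown sit.

Going by these compounds, whether 4-methylphenyl, 2-cyanophenyl and 3-chlorophenyl differ at all on this read-out stays open.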